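A few compounds are considered here, and "the series" means these few. Any claim that something is new, unique, unknown or untested is made for them only; others in the source may bear on it.

In a functional assay on U-937 cells (Homo sapiens) for cytotoxicity, read by CCK-8 assay, with a stated time of 72 h (a higher number here means a weaker inhibitor, a lower number a stronger inhibitor), compound 1 `C=CCn1c(=O)/c(=C\c2cccc(Cl)c2)[nH]c(=O)/c1=C\c1ccccc1OC` was measured. In this assay compound 1 gives 1200 nM. Compound 2 `COc1ccccc1/C=c1/[nH]c(=O)/c(=C\c2ccccc2OC)n(C)c1=O` gives 1500 nM in this assay, and the two numbers sit within the scatter of each other, so compound 1 holds the lower of the two numbers without a claim of order. Compound 3 `COc1ccccc1/C=c1/[nH]c(=O)/c(=C\c2cccc(Cl)c2Cl)[nH]c1=O` was reported as "not active" (no number reported) in this assay, with no number given.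

The reviewer now turns to compound 4 `C=CCn1c(=O)/c(=C\c2cccc(F)c2)[nH]c(=O)/c1=C\c1ccccc1OC`, which differs from compound 1 in one place: fluoro in place of chloro on an aromatic carbon. Going by the values given here, no pair among the measured compounds shows this kind of swap, so nothing here sets its size. The reviewer expects a step of a 1.5-fold higher number from compound 1 to compound 4 (0.18 log units; within the scatter), not beyond the scatter, in this assay. Compound 4 is estimated at 1800 nM, with a range from 700 nM to 5000 nM.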

Compound 4, half-maximal inhibitory concentration: 2500 nM
For compound 4 the middle estimate is 1.4-fold (0.14 log units) below the measured one, and the stated range covers the measured number.
By their numbers in this assay, from the lowest: compounds 1, 2 and 4 (each within the scatter of the next, the first and the last beyond it).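

Going by these compounds alone, replacing chloro with fluoro on this aromatic carbon gives the first step that can be read between measured compounds, a 2.1-fold higher number from compound 1 to compound 4 (0.32 log units; beyond the scatter), in this assay. The step is modest but beyond the scatter, so this position does register the swap of one halogen for the other, while compound 4 still gives a measurable number. Nothing measured here explains the step. The compounds shown leave open how a bare phenyl, or an amine or carboxylic acid on this same carbon, would read. They also leave open whether the swap gives a similar step with the allyl group replaced.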